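This account rests on a few compounds, and the source may have more. Where it says the series, first, only, none or still open, it means among the compounds named here.

Of the compounds shown here, two have so far been measured in a functional assay on DU-145 cells (Homo sapiens) for cytotoxicity, read by MTT assay, with a stated time of 2 days; a higher number here means a weaker inhibitor, a lower number a stronger inhibitor. Compound 1 `CCCCCNc1nc(NCc2ccco2)c2cc(F)ccc2n1` carries a plain alkyl chain on one amine of the shared core; in this assay compound 1 gives 7240 nM. Compound 2 `Fc1ccc2nc(NCCCCN3CCN(c4cccc(Cl)c4Cl)CC3)nc(NCc3ccco3)c2c1` replaces that chain with a longer linker ending in a six-membered non-aromatic ring with two nitrogens, which in turn bears a 2,3-dichlorophenyl group; in this assay compound 2 gives 670 nM. That is the lower of the two numbers, and the gap to compound 1 lies beyond the usual scatter, so compound 2 counts as the stronger inhibitor of the pair.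

Compound 3 `Cc1cccc(N2CCN(CCCCNc3nc(NCc4ccco4)c4cc(F)ccc4n3)CC2)c1C` keeps everything of compound 2 except one group: 2,3-dimethylphenyl in place of 2,3-dichlorophenyl on an amine nitrogen in a ring. Among the measured compounds shown here, no measured pair isolates exactly this exchange, so there is no measured step to lean on; both aryl groups are counted with the same number of heavy atoms and neither carries a donor or an acceptor. The expected step is a 1.5-fold higher number from compound 2 to compound 3 (0.17 log units; within the scatter), small, toward a slightly weaker inhibitor or none beyond the scatter. Compound 3 is therefore estimated at 1000 nM in this assay, within a range from 400 nM to 2500 nM.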

Compound 3, half-maximal inhibitory concentration: 3320 nM
The estimate for compound 3 lay 3.3-fold (0.52 log units) below the measured number; the measured number lies above the stated range.
By their numbers in this assay, from the lowest: compound 2; then compound 3; then compound 1.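

In this assay, the aryl group on the amine nitrogen of the ring turns out to matter: 2,3-dimethylphenyl in place of 2,3-dichlorophenyl gives a 5.0-fold higher number from compound 2 to compound 3 (0.70 log units; beyond the scatter), which makes compound 3 the weaker inhibitor of this pair. The two groups match in everything counted here, with the same number of heavy atoms, one six-membered aromatic ring of carbon only, and no hydrogen-bond donors or acceptors, so these counts do not predict the size of the step; the visible difference is chlorine in one group and carbon in the other. Nothing available here accounts for the loss in this cell assay.

From the compounds shown here alone, it remains open how a plain phenyl, a phenyl with a single chlorine or a single methyl, or a phenyl with methoxy groups would compare with these two aryl groups. Going by these compounds, it is also open whether the same exchange would give a step of similar size on a shorter or longer chain between the shared core and the ring.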